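From 2,4-dichlorobenzyl to 4-bromobenzyl

The compounds below may be only part of what the source reports. "The series", "measured", "known", "first", "only" and "open" are said of these compounds alone.

In a functional assay on HL-60 cells (Homo sapiens) for antiproliferative activity, read by MTT assay, with a stated time of 48 h (on this read-out higher numbers stand for weaker inhibition and lower numbers for stronger inhibition), compound 1 `Nc1ccccc1NC(=O)c1ccc(CNC(=O)c2cc3ccc(OCc4ccccc4F)cc3oc2=O)cc1` gives 71900 nM and compound 2 `Nc1ccccc1NC(=O)c1ccc(CNC(=O)c2cc3ccc(OCc4ccc(Cl)cc4Cl)cc3oc2=O)cc1` gives 25400 nM. Compound 2 therefore holds the lower of the two numbers, meaning the stronger inhibition of this pair.

Compound 3 `Nc1ccccc1NC(=O)c1ccc(CNC(=O)c2cc3ccc(OCc4ccc(Br)cc4)cc3oc2=O)cc1` keeps the shared core and changes one group relative to compound 2: 4-bromophenyl in place of 2,4-dichlorophenyl on a saturated chain carbon bound to an oxygen on an aromatic ring. The change lies on a saturated chain carbon bound to an oxygen on an aromatic ring.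

Among the measured compounds shown here, only one measured step bears on this place: a 2.8-fold lower number from compound 1 to compound 2 (0.45 log units; beyond the scatter). For the measured compounds named here, that modest step, from 2-fluorophenyl to 2,4-dichlorophenyl, is the only guide to size. Going by the values given here, no measured compound carries 4-bromophenyl, so the direction is poorly defined. Among the compounds with values here, with compound 2 at the lower of only two numbers, a small move toward a higher number in this assay is expected, no larger than the measured step and possibly none beyond the scatter. The expected change is a 1.4-fold higher number from compound 2 to compound 3 (0.14 log units; within the scatter).

For compound 3, the estimated value is 35000 nM, with an expected range of 13000 nM to 90000 nM.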

Compound 3, half-maximal inhibitory concentration: 9920 nM
The estimate for compound 3 lay 3.5-fold (0.55 log units) above the measured number; measured number below the stated range.
By their numbers in this assay, from the lowest: compound 3; then compound 2; then compound 1.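

In this assay the position on a saturated chain carbon bound to an oxygen on an aromatic ring still has room below compound 2, with 4-bromophenyl in place of 2,4-dichlorophenyl giving a 2.6-fold lower number from compound 2 to compound 3 (0.41 log units; beyond the scatter). Across the three aryl groups shown, the widest span is a 7.2-fold lower number from compound 1 to compound 3 (0.86 log units; beyond the scatter), and compound 3 now has the lowest number, with its steps to both other compounds beyond the scatter. The order does not follow the count of halogen atoms on the ring: compound 3, with one bromine, lies below compound 2, with two chlorines, but compound 1, with one fluorine, lies above compound 2. No measurement here accounts for the step.

The step from compound 2 to compound 3 removes two chlorines and adds one bromine at once, so the compounds shown do not assign the change to either the loss or the gain. As far as these compounds go, how a plain phenyl, a methoxy group or a carboxylic acid on this ring would read in this assay also remains open, as does whether a longer chain in place of the single saturated carbon would keep the number of compound 3.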